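The source may hold more compounds than are shown below. What is called first, only, known or untested is meant among the compounds shown, and "the series" means these compounds.

Three compounds share a core carrying an amine-substituted benzamide. Compound 1 `NS(=O)(=O)Oc1ccc2c(c1)CN(C(=O)c1ccc(N3CCCCC3)cc1)CC2` gives 11.5% in an assay on HEK293 cells for inhibition of Steryl-sulfatase (Homo sapiens), tested at 0.1 uM; on this read-out higher numbers stand for a stronger effect at the one concentration tested and lower numbers for a weaker effect. Compound 2 `CN(C)CCN(CCN(C)C)c1ccc(C(=O)N2CCc3ccc(OS(N)(=O)=O)cc3C2)cc1` gives 3.8% in this assay, a change of a number 7.7 percentage points lower from compound 1 to compound 2 (within the scatter). Compound 3 `CCCN(CCC)c1cccc(C(=O)N2CCc3ccc(OS(N)(=O)=O)cc3C2)c1` gives 8.3% in this assay, placing it second of the three, close to compound 1 and to compound 2, with all three numbers inside the usual scatter of one another. Compound 4 `CCN(Cc1cccnc1)c1cccc(C(=O)N2CCc3ccc(OS(N)(=O)=O)cc3C2)c1` has not been measured; it differs from compound 3 by ethyl((pyridin-3-yl)methyl)amino in place of dipropylamino on an aromatic carbon. Among the measured compounds shown here, the only measured step, from compound 1 to compound 2, also swaps one amine for another and stays within scatter, so no step beyond scatter is expected in this assay. Compound 4 is therefore estimated at 8%, between 0% and 20%, a step of a number 0.3 percentage points lower from compound 3 to compound 4 (within the scatter).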

Compound 4, a percentage reported as inhibition, at one concentration (the size of the read-out at that concentration, not a potency): 14.3%
Compound 4: middle estimate off by 6.3 percentage points, on the low side; the measured number falls inside the stated range.
By their numbers in this assay, from the lowest: compounds 2, 3, 1 and 4 (each within the scatter of the next, the first and the last beyond it).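

On an aromatic carbon meta to a large group, ethyl((pyridin-3-yl)methyl)amino in place of dipropylamino gives a number 6 percentage points higher from compound 3 to compound 4 (within the scatter) in this assay at this position. Among the compounds shown here, the amine here can thus carry a six-membered aromatic ring with 1 hetero atom without a step beyond the scatter, which the earlier compounds, with no aromatic ring on their amines, did not show. No available data bear on the reason for this result. Still open, from the compounds shown here alone, is whether a benzyl group or a carboxylic acid on this amine would give a step beyond the scatter.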